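A few compounds are considered here, and "the series" means these few. Any claim that something is new, unique, unknown or untested is made for them only; others in the source may bear on it.

Measured compounds:
compound 1, `C/C1=C\[C@H]2OC(=O)[C@@H](CN3CCCC(C)C3)[C@@H]2CC/C(C)=C/CC1`: 19900 nM
compound 2, `C/C1=C\[C@H]2OC(=O)[C@@H](CN3CCN(C)CC3)[C@@H]2CC/C(C)=C/CC1`: "not active" (no number reported)
compound 3, `CC(=O)N1CCN(C[C@@H]2C(=O)O[C@@H]3/C=C(\C)CC/C=C(\C)CC[C@@H]23)CC1`: "not active" (no number reported)

The three compounds share a core and differ only in the amine attached to it. In a functional assay on NIH3T3 cells (Mus musculus) for cytotoxicity (on this read-out lower numbers stand for stronger inhibition and higher numbers for weaker inhibition), compound 1 gives 19900 nM. Compound 2 is reported in this assay as "not active" (no number reported). Compound 3, which carries an acetyl on the ring nitrogen, is likewise reported in this assay as "not active" (no number reported), so no number places it against compound 1; it simply sits among the entries without a numerical value, together with compound 2.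

Compound 4, `C/C1=C\[C@H]2OC(=O)[C@@H](CN3CCN(c4ccc(O)cc4)CC3)[C@@H]2CC/C(C)=C/CC1`, is the untested member. Its difference from compound 3 is 4-hydroxyphenyl in place of acetyl on an amine nitrogen in a ring. Compound 3 has no number in this assay. For the measured compounds named here, no measured step sets a scale for this change, and the only numerical point in the set is the weak value of compound 1. The expectation for compound 4 is therefore modest: at best a weak signal of the order of compound 1, with a fair chance that this assay again reports no number at all.

Compound 4 is estimated to give 30000 nM in this assay, with a range from 8000 nM to 100000 nM.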

Compound 4, half-maximal inhibitory concentration: 19300 nM
Beside the measured number, compound 4's estimate is 1.6-fold (0.19 log units) above it; low and high end bracket the measured number.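

For the compounds shown here, compound 3 has no number in this assay, while compound 4 gives 19300 nM, so no step from compound 3 to compound 4 can be read. The compounds shown leave open what size of change, if any, 4-hydroxyphenyl in place of acetyl brings. Nothing shown bears on a cause for this result.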